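From methoxycarbonyl to carboxy on the shared core

A few compounds are considered here, and "the series" means these few. Any claim that something is new, unique, unknown or untested is made for them only; others in the source may bear on it.

In an ADME assay on L929 cells (Mus musculus) for cytotoxicity, read by resazurin assay, with a stated time of 48 h (on this read-out lower numbers stand for higher toxicity in this test and higher numbers for lower toxicity in this test), compound 1 `C=CCn1c2ccc([N+](=O)[O-])cc2c(=O)n1Cc1ccccc1` gives 192000 nM. Compound 2 `COC(=O)CCn1c2ccc([N+](=O)[O-])cc2c(=O)n1Cc1ccccc1` gives > 256000 nM, which is a limit of the assay and not a number. Compound 2 therefore has no exact place in the series.

The next structure is compound 3 `O=C(O)CCn1c2ccc([N+](=O)[O-])cc2c(=O)n1Cc1ccccc1`. The difference is hydrogen in place of methyl on an oxygen next to a carbonyl group, so that methoxycarbonyl becomes carboxy.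

Going by the values given here, only one measured step bears on this change, and only indirectly. It is an at least 1.3-fold higher number from compound 1 to compound 2 (0.12 log units; that floor lies within the scatter), with (methoxycarbonyl)methyl in place of vinyl on a saturated chain carbon bound to an aromatic nitrogen. That step touches the same chain but does not test the exchange on the oxygen. It gives no sign of a large shift in this assay, so no direction is favoured for compound 3.

The expected change is a step that the limit leaves unreadable from compound 2 to compound 3, and no step beyond the scatter is expected. For compound 3 the estimate is 280000 nM, with an expected range of 130000 nM to 500000 nM.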

Compound 3, concentration lethal to 50% of the cells: > 256000 nM
Compound 3 gave a limit, no number; the forecaster's own chance of this, stated with the estimate: 65%; the middle value is on the limit's open side.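

In this assay compound 3 reaches the same limit as compound 2, and this is a limit of the assay rather than a number: the limit of > 256000 nM in this assay, at which 2 of the 3 values shown sit.

Both ends of the exchange of hydrogen for methyl on an oxygen next to a carbonyl group are therefore limits, so that step cannot be read. The comparison with the vinyl end of the chain gives an at least 1.3-fold higher number from compound 1 to compound 3 (0.12 log units; that floor lies within the scatter). What compound 3 adds is that the carboxy form of this chain, like the methoxycarbonyl form, stays at the limit and does not come down into the readable range of this test.

On these data alone, how far compound 2 and compound 3 each lie past the limit remains open, and so does whether the exchange from methoxycarbonyl to carboxy changes anything at all in this test. Also open, as far as these compounds go, is whether an amide, an amine or a longer chain ending in carboxy, in place of carboxymethyl, would give a readable number or would sit at the same limit.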